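Anilide variation at the carbonyl carbon: compound 4

This account rests on a few compounds, and the source may have more. Where it says the series, first, only, none or still open, it means among the compounds named here.

Compound 1 `CCC(=O)Nc1ccc(N2CCN(c3ccc(OC[C@@H]4CO[C@@](Cn5cncn5)(c5ccc(Cl)cc5Cl)O4)cc3)CC2)cc1` sets the reference point: in a functional assay on A549 cells (Homo sapiens) for inhibition, read by MTT assay, with a stated time of 48 h (a lower number here means a stronger inhibitor, a higher number a weaker inhibitor), compound 1 gives 2550 nM. Compound 2 `O=C(CC1CCOCC1)Nc1ccc(N2CCN(c3ccc(OC[C@@H]4CO[C@@](Cn5cncn5)(c5ccc(Cl)cc5Cl)O4)cc3)CC2)cc1`, with oxan-4-yl in place of methyl on the saturated chain carbon bound to the carbonyl carbon, gives 10000 nM, a change of a 3.9-fold higher number from compound 1 to compound 2 (0.59 log units; beyond the scatter). Compound 3 `O=C(CCc1ccccc1)Nc1ccc(N2CCN(c3ccc(OC[C@@H]4CO[C@@](Cn5cncn5)(c5ccc(Cl)cc5Cl)O4)cc3)CC2)cc1`, with phenyl two bonds along the chain from the carbonyl carbon, gives 2060 nM, a change of a 1.2-fold lower number from compound 1 to compound 3 (0.09 log units; within the scatter). Compound 2 therefore stands highest of the three numbers, with compound 1 nearest and compound 3 furthest, the latter gap being a 4.9-fold lower number from compound 2 to compound 3 (0.69 log units; beyond the scatter).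

Compound 4 `O=C(Nc1ccc(N2CCN(c3ccc(OC[C@@H]4CO[C@@](Cn5cncn5)(c5ccc(Cl)cc5Cl)O4)cc3)CC2)cc1)c1ccc(F)c(F)c1` differs from compound 2 by 3,4-difluorophenyl in place of (oxan-4-yl)methyl on a carbonyl carbon. Going by the values given here, the steps that bear on this are the two that alter the group on the carbonyl carbon: a 3.9-fold higher number from compound 1 to compound 2 (0.59 log units; beyond the scatter) and a 4.9-fold lower number from compound 2 to compound 3 (0.69 log units; beyond the scatter), both modest and both beyond the scatter. Each move away from the oxan-4-yl group has brought the number back to the level shared by compound 1 and compound 3. Among the compounds with values here, an aromatic ring attached directly to the carbonyl carbon has no measured counterpart, so the direction rests only on compound 2 being the highest number. The step from compound 2 to compound 4 is expected to be a 4.0-fold lower number from compound 2 to compound 4 (0.60 log units; beyond the scatter), a modest lowering. Compound 4 is estimated at 2500 nM, with a range of 1000 nM to 8000 nM.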

Compound 4, half-maximal inhibitory concentration: 8690 nM
Beside the measured number, compound 4's estimate is 3.5-fold (0.54 log units) below it, outside the stated range (above it).
By their numbers in this assay, from the lowest: compounds 3 and 1 (each within the scatter of the next); then compounds 4 and 2 (each within the scatter of the next).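

On a carbonyl carbon whose other neighbour is an amide-type nitrogen, 3,4-difluorophenyl in place of (oxan-4-yl)methyl gives no readable change in this assay, with a 1.2-fold lower number from compound 2 to compound 4 (0.06 log units; within the scatter) within the scatter, so the weak end of the series no longer rests on the oxan-4-yl group alone. The two other compounds stay clearly apart from this level, with a 3.4-fold higher number from compound 1 to compound 4 (0.53 log units; beyond the scatter) and a 4.2-fold higher number from compound 3 to compound 4 (0.63 log units; beyond the scatter), so the four compounds now fall into two levels: ethyl and phenethyl on the carbonyl carbon at the lower numbers, (oxan-4-yl)methyl and 3,4-difluorophenyl at the higher ones. Nothing measured here accounts for this split into two levels.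

Going by these compounds, it remains open whether the higher number of compound 4 goes with the ring standing directly on the carbonyl carbon or with its two fluorines, a question that an unsubstituted phenyl on that carbon would separate. On these data alone, it is also open whether a benzyl group, one carbon shorter than the phenethyl of compound 3, stays at the lower level, and how a chain ending in an amine or a carboxylic acid would read.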